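Cytotoxicity notes on the biaryl amide series, compound 4

The source may hold more compounds than are shown below. What is called first, only, known or untested is meant among the compounds shown, and "the series" means these compounds.

Compound 1 `CCOC(=O)CCCCCOc1cccc(CN(C(=O)c2ccc(-c3cccc(OC(C)C)c3)cc2)C(C)C)c1` carries a 3-isopropoxyphenyl on the shared core. In an ADME assay on Raji cells (Homo sapiens) for cytotoxicity, read by CellTiter-Glo and resazurin assay, with a stated time of 72 h (a lower number here means that less compound is needed, a higher number that more compound is needed for the effect), compound 1 gives > 26000 nM, a limit of the assay and not a number. Compound 2 `CCOC(=O)CCCCCOc1cccc(CN(C(=O)c2ccc(-c3cccc(Oc4ccccc4)c3)cc2)C(C)C)c1` has phenyl in place of isopropyl on an oxygen on an aromatic ring. In this assay compound 2 gives > 19600 nM, again a limit. Compound 3 `CCOC(=O)CCCCCOc1cccc(CN(C(=O)c2ccc(-c3cccc(OCc4ccccc4)c3)cc2)C(C)C)c1` has benzyl in place of isopropyl on an oxygen on an aromatic ring. In this assay compound 3 gives > 26000 nM, also a limit. Every value of the set sits at the limit of > 26000 nM in this assay, at which 2 of the 3 values shown sit, or at the limit of > 19600 nM in this assay, at which 1 of the 3 values shown sits, so the steps a step that the two limits leave unreadable from compound 1 to compound 2, a step that the two limits leave unreadable from compound 1 to compound 3 and a step that the two limits leave unreadable from compound 2 to compound 3 cannot be read in size or direction.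

Compound 4 `CCOC(=O)CCCCCOc1cccc(CN(C(=O)c2ccc(-c3ccc(Cl)c(Cl)c3)cc2)C(C)C)c1` differs from compound 1 by 3,4-dichlorophenyl in place of 3-isopropoxyphenyl on an aromatic carbon. Within the data shown here, no measured step bears directly on this exchange, and none of the three measured steps yields a readable size; the only guide is that all values shown are limits. The expectation for compound 4 in this assay is therefore another limit rather than a number, with a step of about a number no higher from compound 1 to compound 4 (the limit leaves the size open) expected. Compound 4 is estimated at 26000 nM, within 9000 nM to 70000 nM.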

Compound 4, half-maximal effective concentration: > 26000 nM
Compound 4: only a limit was reported (the forecaster's own chance of this, stated with the estimate: 80%); the middle value lies on the limit itself.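

Compound 4 gives > 26000 nM in this assay as a limit and not a number. Compound 1 and compound 4 sit at the same limit, and the step between them cannot be read: the limit of > 26000 nM in this assay, at which 3 of the 4 values shown sit.

The compounds shown leave open at what concentration, if any, compound 1, compound 2, compound 3 or compound 4 reaches the half-maximal effect in this assay and whether 3,4-dichlorophenyl in place of 3-isopropoxyphenyl changes it.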